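From Methyl to Hydrogen on a Shared Core

The source may report more compounds than this note shows. Statements on the series, on what has been measured and on what is new or still open speak of the compounds shown alone.

Of the compounds shown here, two have been measured so far in a functional assay on Vero cells (Chlorocebus sabaeus) for cytotoxicity; on this read-out lower numbers stand for stronger inhibition and higher numbers for weaker inhibition. Compound 1 `Nc1ccn([C@@H]2CC(F)(F)[C@H](CO)O2)c(=O)n1` gives > 100000 nM, which is a limit of the assay and not a number. Compound 2 `Cc1cn([C@@H]2CC(F)(F)[C@H](CO)O2)c(=O)nc1O` gives > 100000 nM, which is also a limit and not a number. Compound 2 therefore has no exact value and stands at the limit of > 100000 nM in this assay, at which 2 of the 2 values shown sit.

Compound 3 `O=c1nc(O)ccn1[C@@H]1CC(F)(F)[C@H](CO)O1` differs from compound 2 by one change: hydrogen in place of methyl on an aromatic carbon. For the measured compounds named here, no measured pair shows what this change does in this assay, and compound 2 offers only its limit of > 100000 nM as a guide. The expected step of a number no higher from compound 2 to compound 3 (the limit leaves the size open) is none beyond the scatter, in either direction. The estimated value for compound 3 is 100000 nM, with an expected range from 50000 nM to 200000 nM, and it will most likely be reported as a limit again.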

Compound 3, half-maximal inhibitory concentration: > 100000 nM
Compound 3 gave a limit, no number; the forecaster's own chance of this, stated with the estimate: 90%; the middle value sits exactly at the limit.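

In this assay compound 3 gives a limit and not a number, so its steps from compound 2 and from compound 1 cannot be read. The compounds shown leave open whether hydrogen in place of methyl, or hydroxy in place of amino, changes this read-out at all.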